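From methyl to carbamoyl on a saturated ring carbon

The compounds below may be only part of what the source reports. "The series", "measured", "known", "first", "only" and "open" are said of these compounds alone.

Compound 1 `CC1CCN(c2c(S(=O)(=O)c3ccccc3)cnc3ccccc23)CC1` gives 89.2% in an assay on isolated protein for displacement of a labelled ligand from metabotropic glutamate receptor 5 (Homo sapiens), with a stated time of 60 min, tested at 1 uM (a higher number here means more inhibition at the concentration tested (going by the name of the read-out), a lower number less inhibition), the highest of the two numbers in hand, yet its nearest neighbour, compound 2 `CC1CCN(c2c(S(=O)(=O)c3ccccc3)cnc3cc(F)ccc23)CC1`, gives 87% in this assay, and the step of a number 2.2 percentage points lower from compound 1 to compound 2 (within the scatter) separates the two only within the scatter. The unmeasured compound 3 `NC(=O)C1CCN(c2c(S(=O)(=O)c3ccccc3)cnc3ccccc23)CC1` departs from compound 1 by carbamoyl in place of methyl on a saturated ring carbon. Going by the values given here, only one measured step exists, and it concerns a fluoro entering for hydrogen on an aromatic carbon, not the saturated ring where the present change sits, so no measured step bears directly on it. Among the compounds with values here, with the single step known being flat, the account has nothing to anchor a direction for a change that exchanges a small group for one with a donor and an acceptor. The author therefore expects a loss that may exceed the scatter, but with wide uncertainty. Compound 3 is estimated to give 68% in this assay, ranging from 35% to 92%. The expected step is a number 21.2 percentage points lower from compound 1 to compound 3 (beyond the scatter).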

Compound 3, a percentage reported as inhibition, at one concentration (the size of the read-out at that concentration, not a potency): 24.8%
Beside the measured number, compound 3's estimate is 43.2 percentage points above it; measured number outside the range, below it.
By their numbers in this assay, from the lowest: compound 3; then compounds 2 and 1 (each within the scatter of the next).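

In this assay, the exchange of 4-methylpiperidin-1-yl for 4-carbamoylpiperidin-1-yl gives a number 64.4 percentage points lower from compound 1 to compound 3 (beyond the scatter), which shows that the read-out is sensitive to the group on this saturated ring carbon, three ring bonds from the ring nitrogen. Going by these compounds alone, the only earlier step, fluoro in place of hydrogen on an aromatic carbon elsewhere in the molecule, gave a number 2.2 percentage points lower from compound 1 to compound 2 (within the scatter) and so showed no such sensitivity. Nothing on hand accounts for the loss at the piperidine position, and the size of the step is all that can be stated.

This single pair does not separate the parts of the change, since the entering carbamoyl differs from methyl at once in its heavy atoms, its hydrogen-bond donor and its hydrogen-bond acceptor. Going by these compounds, it remains open how an ethyl group or a longer alkyl chain, a hydroxyl, an amine or a carboxylic acid on the same ring carbon would read in this assay, and so whether the loss is particular to the carbamoyl or extends to other groups at this place.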